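Truncating the butynyl chain on the shared core

The source may report more compounds than this note shows. Statements on the series, on what has been measured and on what is new or still open speak of the compounds shown alone.

Three compounds carry the same core with a trimethoxybenzyl arm and differ only in the group on the aromatic nitrogen. Compound 1 `COc1cc(Cc2nc3c(N)ncnc3n2CC2CCCCC2)cc(OC)c1OC` gives 39800 nM in a functional assay on MCF7 cells (Homo sapiens) for antiproliferative activity; a lower number here means a stronger inhibitor, a higher number a weaker inhibitor. Compound 2 `COc1cc(Cc2nc3c(N)ncnc3n2CC(C)C)cc(OC)c1OC` gives 97700 nM in this assay, and compound 3 `C#CCCCn1c(Cc2cc(OC)c(OC)c(OC)c2)nc2c(N)ncnc21` gives 24000 nM in this assay. Compound 3 stands at the low end of the three numbers, with compound 1 close enough to be within the scatter and compound 2 clearly apart: a 1.7-fold lower number from compound 1 to compound 3 (0.22 log units; within the scatter), a 4.1-fold lower number from compound 2 to compound 3 (0.61 log units; beyond the scatter), while a 2.5-fold higher number from compound 1 to compound 2 (0.39 log units; beyond the scatter).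

Compound 4 `CCn1c(Cc2cc(OC)c(OC)c(OC)c2)nc2c(N)ncnc21` is not yet measured. The change from compound 3 is hydrogen in place of propargyl on a saturated chain carbon, two bonds along the chain from an aromatic nitrogen. The measured steps all concern the same nitrogen substituent; the two steps beyond the scatter point to the but-3-yn-1-yl group giving the lower number, so removing most of it is expected to raise the number modestly. For compound 4 the expected step is a 2.5-fold higher number from compound 3 to compound 4 (0.40 log units; beyond the scatter), so the estimate for compound 4 in this assay is 60000 nM, within 25000 nM to 150000 nM.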

Compound 4, half-maximal inhibitory concentration: 79400 nM
Compound 4: middle estimate off by 1.3-fold (0.12 log units), on the low side, and the stated range covers the measured number.
By their numbers in this assay, from the lowest: compounds 3, 1, 4 and 2 (each within the scatter of the next, the first and the last beyond it).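

Removing the propargyl part to leave the ethyl group on the aromatic nitrogen gives up the low number of compound 3 in this assay (a 3.3-fold higher number from compound 3 to compound 4 (0.52 log units; beyond the scatter)). The short chain of compound 4 does not separate from the isopropyl-bearing or the cyclohexyl-bearing substituent (a 1.2-fold lower number from compound 2 to compound 4 (0.09 log units; within the scatter); a 2.0-fold higher number from compound 1 to compound 4 (0.30 log units; within the scatter)), so compounds 1, 2 and 4 give no clear order among themselves, and compound 3 stands apart from compounds 2 and 4 but not from compound 1. No measurement shown gives a reason for the step at this position.

As far as these compounds go, whether the step follows the triple bond or the chain length stays open, and a saturated butyl or pentyl chain at this nitrogen would separate the two. Equally open, from the compounds shown here alone, is how an amine or a carboxylic acid at the end of the chain would read here.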